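Isopropyl for methyl on the amine nitrogen in this series

This account rests on a few compounds, and the source may have more. Where it says the series, first, only, none or still open, it means among the compounds named here.

Compound 3 `CNN(C)c1nnc(-c2ccccc2C)s1` gives 10 mg/kg in a functional assay on the whole organism with Mus musculus as the target, in the maximal electroshock model, with a stated time of 1 h (on this read-out lower numbers stand for an effect already at smaller amounts and higher numbers for an effect only at larger amounts of compound), the lowest of the two numbers. Its nearest neighbour is compound 1 `Cc1ccccc1-c1nnc(N(N)C(C)C)s1` with 54 mg/kg; the step of a 5.4-fold lower number from compound 1 to compound 3 (0.73 log units; beyond the scatter). Compound 2 `CNNc1nnc(-c2ccccc2C)s1` reaches only the limit > 100 mg/kg, and a limit it stays (the limit of > 100 mg/kg in this assay, at which 1 of the 3 values shown sits). The step of an at least 10-fold lower number from compound 2 to compound 3 (1.00 log units; beyond the scatter) shows that a methyl on the nitrogen on the aromatic ring matters. Compound 4 `Cc1ccccc1-c1nnc(N(C)NC(C)C)s1` differs from compound 3 by isopropyl in place of methyl on an amine nitrogen. For the measured compounds named here, no measured step changes the outer nitrogen alone: the step from compound 1 to compound 3 moves isopropyl off the ring nitrogen and adds methyl on the outer one together, while compound 2 to compound 3 touches the ring nitrogen only. Compound 4 keeps the ring-nitrogen methyl that carried the two measured gains, so the expectation is a step of a 1.8-fold higher number from compound 3 to compound 4 (0.26 log units; within the scatter) of modest size at most, within or near the scatter. Compound 4 is therefore estimated at 18 mg/kg, between 7 mg/kg and 50 mg/kg.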

Compound 4, dose for half-maximal effect: 35 mg/kg
The estimate for compound 4 lay 1.9-fold (0.29 log units) below the measured number; low and high end bracket the measured number.
By their numbers in this assay, from the lowest: compound 3; then compounds 4 and 1 (each within the scatter of the next). At a limit, above all of these: compound 2.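

In this assay, for the compounds shown here, this is the first step that changes the outer amine nitrogen alone while the methyl on the nitrogen on the aromatic ring stays in place, and isopropyl in place of methyl there gives a readable loss: a 3.5-fold higher number from compound 3 to compound 4 (0.54 log units; beyond the scatter). With a limit at one end, the next step is only a floor, yet it still lies beyond the scatter: an at least 2.8-fold lower number from compound 2 to compound 4 (0.45 log units; beyond the scatter). Where the isopropyl sits and whether the methyl is present together give no difference that can be read: a 1.5-fold lower number from compound 1 to compound 4 (0.19 log units; within the scatter).

Only methyl and isopropyl have been compared on the outer nitrogen with the ring-nitrogen methyl kept, and two groups make no trend. As far as these compounds go, whether ethyl, cyclopropyl or a longer chain such as n-butyl would fit between or beyond them remains open.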